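Trifluoromethyl for Acetyl on a Biaryl Amide Series

The source may hold more compounds than are shown below. What is called first, only, known or untested is meant among the compounds shown, and "the series" means these compounds.

Measured so far in an ADME assay on Raji cells (Homo sapiens) for cytotoxicity, read by CellTiter-Glo and resazurin assay, with a stated time of 72 h; a lower number here means that less compound is needed, a higher number that more compound is needed for the effect:
compound 1, `CC(C)N(Cc1cccc(OCCCCCC(=O)O)c1)C(=O)c1ccc(-c2ccc3c(c2)OCCO3)cc1`, a limit: > 21900 nM
compound 2, `CCOC(=O)CCCCCOc1cccc(CN(C(=O)c2ccc(-c3cccc(C(C)=O)c3)cc2)C(C)C)c1`, a limit: > 26000 nM
compound 3, `CCOC(=O)CCCCCOc1cccc(CN(C(=O)c2ccc(-c3cn(S(=O)(=O)c4ccccc4)c4ccccc34)cc2)C(C)C)c1`, a limit: > 26000 nM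

None of the three values is a number; each is a limit of the assay. Compound 2 stands at the limit of > 26000 nM in this assay, at which 2 of the 3 values shown sit. Compound 3 shares that limit. Compound 1 stands at the limit of > 21900 nM in this assay, at which 1 of the 3 values shown sits. With only limits shown, no ordering among the three can be drawn, and no measured step exists to calibrate the next change.

Compound 4, `CCOC(=O)CCCCCOc1cccc(CN(C(=O)c2ccc(-c3cccc(C(F)(F)F)c3)cc2)C(C)C)c1`, differs from compound 2 in one place: trifluoromethyl in place of acetyl on an aromatic carbon. Among the compounds with values here, since every value so far is a limit, the expected step that the limit leaves unreadable from compound 2 to compound 4 is none beyond the scatter. Compound 4 is therefore estimated at 30000 nM, expected between 15000 nM and 60000 nM, most likely reported again only as a limit.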

Compound 4, half-maximal effective concentration: > 26000 nM
Compound 4 gave a limit, no number (the forecaster's own chance of this, stated with the estimate: 85%); the middle value lies beyond the limit too.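

Within the data shown here, compound 2 and compound 4 each gave only a limit of the assay, and no step between them can be read. The compounds shown leave open the concentration at which any of them reaches its half-maximal effect in this assay.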